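From fluoro to trifluoromethoxy on a shared core

A few compounds are considered here, and "the series" means these few. Any claim that something is new, unique, unknown or untested is made for them only; others in the source may bear on it.

Within the data shown here, in an ADME assay for permeability, using PAMPA, with a stated time of 18 h, tested at 25 ug/mL (a higher number here means that the compound crosses the layer faster, a lower number that the compound crosses the layer more slowly), compound 1 `Brc1ccc(CNC2CCN(Cc3ccccc3)C2)cc1` gives 5.1 10^-6 cm/s and compound 2 `Fc1ccc(CNC2CCN(Cc3ccccc3)C2)cc1` gives 4.2 10^-6 cm/s, so compound 2 stands within the scatter of the only other measured compound. Compound 3 `FC(F)(F)Oc1ccc(CNC2CCN(Cc3ccccc3)C2)cc1` carries trifluoromethoxy in place of fluoro on an aromatic carbon. Among the measured compounds shown here, the one measured step that bears on this change is an exchange at the same place, fluoro in place of bromo, a 1.2-fold lower number from compound 1 to compound 2 (0.08 log units; within the scatter). That single small step gives no reason to expect a change beyond the scatter in this assay, and the expected step is a 1.3-fold higher number from compound 2 to compound 3 (0.12 log units; within the scatter). For compound 3 the estimated value is 5.5 10^-6 cm/s, with an expected range from 2.6 10^-6 cm/s to 11 10^-6 cm/s.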

Compound 3, apparent permeability: 6.9 10^-6 cm/s
The estimate for compound 3 lay 1.3-fold (0.10 log units) below the measured number, within the range that was stated.
By their numbers in this assay, from the lowest: compounds 2, 1 and 3 (each within the scatter of the next).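

In this assay this aromatic carbon takes trifluoromethoxy, with 5 heavy atoms, in place of a single halogen atom without the number leaving the scatter: replacing fluoro gives a 1.6-fold higher number from compound 2 to compound 3 (0.22 log units; within the scatter) and replacing bromo gives a 1.4-fold higher number from compound 1 to compound 3 (0.13 log units; within the scatter) as well. The earlier pair showed this only for an exchange of one halogen for another. No measurement here accounts for this result. Still open, as far as these compounds go, is whether a group of a different kind at this place, such as an amine or a carboxylic acid, would also stay within the scatter.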